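The source may hold more compounds than are shown below. What is called first, only, known or untested is meant among the compounds shown, and "the series" means these compounds.

Measured so far:
- compound 1 `COc1ccc(NS(=O)(=O)/C=C/c2c(OC)cc(OC)cc2OC)cc1`: 75 nM
- compound 2 `COc1cc(OC)c(/C=C/S(=O)(=O)Nc2ccc(OC)c([N+](=O)[O-])c2)c(OC)c1`: 1000 nM
- compound 3 `COC(=O)CNc1cc(NS(=O)(=O)/C=C/c2c(OC)cc(OC)cc2OC)ccc1OC`: 350 nM

In a functional assay on K562 cells (Homo sapiens) for cytotoxicity, read by trypan blue exclusion, with a stated time of 96 h (on this read-out lower numbers stand for stronger inhibition and higher numbers for weaker inhibition), compound 3 gives 350 nM, the second highest of the three numbers. Compound 4 `COC(=O)C(Nc1cc(NS(=O)(=O)/C=C/c2c(OC)cc(OC)cc2OC)ccc1OC)c1ccc(Cl)cc1` has 4-chlorophenyl in place of hydrogen on a saturated chain carbon bound to a carbonyl carbon and a nitrogen on an aromatic ring. Within the data shown here, no measured step changes this chain carbon, so the evidence is indirect. The nitro and ((methoxycarbonyl)methyl)amino replacements both raised the number, as shown by a 13-fold higher number from compound 1 to compound 2 (1.12 log units; beyond the scatter) and a 4.7-fold higher number from compound 1 to compound 3 (0.67 log units; beyond the scatter). Exchanging one for the other gave a 2.9-fold lower number from compound 2 to compound 3 (0.46 log units; beyond the scatter). These steps show that this assay responds to substitution on that aromatic carbon, but they give no direction for a change further out on the chain. The expected change is therefore none beyond the scatter, and the estimated step is a 1.1-fold higher number from compound 3 to compound 4 (0.06 log units; within the scatter). The uncertainty remains wide in both directions. For compound 4 the estimated value is 400 nM, with an expected range of 90 nM to 1800 nM.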

Compound 4, half-maximal inhibitory concentration: 2500 nM
Beside the measured number, compound 4's estimate is 6.3-fold (0.80 log units) below it; measured number outside the range, above it.
By their numbers in this assay, from the lowest: compound 1; then compound 3; then compound 2; then compound 4.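

In this assay, the saturated chain carbon bound to a carbonyl carbon and a nitrogen on an aromatic ring proves sensitive to substitution: 4-chlorophenyl in place of hydrogen gives a 7.1-fold higher number from compound 3 to compound 4 (0.85 log units; beyond the scatter). This is the only step shown on the chain itself, and it establishes that the read-out responds to changes further out than the aromatic carbon, here towards weaker inhibition. No available evidence accounts for this rise.

Still open, on these data alone, is whether the rise belongs to 4-chlorophenyl in particular or to any group on this carbon, a question that a methyl or an unsubstituted phenyl at the same place would help to settle. The series shown also leaves open how the number responds on this chain when a carboxylic acid replaces the methyl ester.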